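Removing the Methyl from the Pyridine-Bearing Thiosemicarbazone

This account rests on a few compounds, and the source may have more. Where it says the series, first, only, none or still open, it means among the compounds named here.

Measured so far:
compound 1 `Cc1cccc(/C(N)=N/NC(=S)N2CCCCC2)n1`: 83.5%
compound 2 `Cc1cccc(/C(N)=N/NC(=S)N2CCCC2)n1`: 79.2%

Of the compounds shown here, two have been measured in a functional assay on HeLa cells (Homo sapiens) for cytotoxicity, read by MTT assay, with a stated time of 72 h, tested at 10 uM; a higher number here means more inhibition of growth at the concentration tested, a lower number less inhibition of growth. Compound 1 gives 83.5%, and compound 2, which differs only at the thiocarbonyl carbon, gives 79.2%. Among the compounds with values here, the one step available, a number 4.3 percentage points lower from compound 1 to compound 2 (within the scatter), is within the scatter, so the two measured compounds cannot be told apart; compound 1 simply stands as one of two numbers that sit together.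

The compound now at hand is compound 3 `N/C(=N\NC(=S)N1CCCCC1)c1ccccn1`. Relative to compound 1 the change is hydrogen in place of methyl on an aromatic carbon, at the position next to the ring nitrogen and meta to a large group. Within the data shown here, no measured step touches this part of the molecule: the only step known concerns the ring on the thiocarbonyl carbon and was itself within the scatter. There is therefore no shown evidence for a shift in either direction, and the account expects the step of a number 7.5 percentage points lower from compound 1 to compound 3 (within the scatter) to stay within the scatter. For compound 3 the estimate in this assay is 76%, with a range from 55% to 92%.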

Compound 3, percent growth inhibition at one concentration: 55.7%
The estimate for compound 3 lay 20.3 percentage points above the measured number; the measured number falls inside the stated range.
By their numbers in this assay, from the lowest: compound 3; then compounds 2 and 1 (each within the scatter of the next).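

Within the data shown here, the methyl on the aromatic carbon next to the ring nitrogen, a place no earlier step had touched, turns out to count in this assay: hydrogen in its place gives a number 27.8 percentage points lower from compound 1 to compound 3 (beyond the scatter). Among these compounds, the only earlier step, a number 4.3 percentage points lower from compound 1 to compound 2 (within the scatter), concerned the ring on the thiocarbonyl carbon and left the compounds indistinguishable, so this is the first change that lies beyond the scatter, and it involves the loss of a single carbon. Nothing presented here explains this loss of growth inhibition, and the account gives no reason for it.

Whether the methyl is special or other groups at this carbon would serve as well stays open, as the compounds shown carry only methyl or hydrogen there; an ethyl group, a methoxy group or an amine at the same place would separate these readings. Going by these compounds, it is also open whether the step carries over to the pyrrolidin-1-yl series, since hydrogen at this place appears here only with piperidin-1-yl on the thiocarbonyl carbon.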